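The compounds below may be only part of what the source reports. "The series", "measured", "known", "first", "only" and "open" are said of these compounds alone.

- compound 1 `C=C1C=CC(=O)[C@@H]2[C@H](Cc3ccc(OCOC)c(F)c3)CC[C@H]12` gives 77.2 nM
- compound 2 `C=C1C=CC(=O)[C@@H]2[C@H](Cc3ccc(F)c(F)c3)CC[C@H]12` gives 233 nM
- compound 3 `C=C1C=CC(=O)[C@@H]2[C@H](Cc3ccc(OC)c(F)c3)CC[C@H]12` gives 0.13 nM

In a functional assay on MCF7 cells (Homo sapiens) for antiproliferative activity, with a stated time of 72 h (on this read-out higher numbers stand for weaker inhibition and lower numbers for stronger inhibition), compound 3 gives 0.13 nM as the lowest of the three numbers, beyond the scatter from both others. Compound 4 `C=C1C=CC(=O)[C@@H]2[C@H](Cc3ccc(OC)c(O)c3)CC[C@H]12` carries hydroxy in place of fluoro on an aromatic carbon ortho to a methoxy group. Among the compounds with values here, no measured step touches that fluoro group, which compound 1, compound 2 and compound 3 all keep. The nearest evidence concerns the other ring substituent, where steps were large (a 1800-fold lower number from compound 2 to compound 3 (3.25 log units; beyond the scatter)) and (a 590-fold lower number from compound 1 to compound 3 (2.77 log units; beyond the scatter)) or modest (a 3.0-fold higher number from compound 1 to compound 2 (0.48 log units; beyond the scatter)). Compound 3 stands so low (0.13 nM) that a sizeable rise is expected, with wide uncertainty. The expected step is a 15-fold higher number from compound 3 to compound 4 (1.19 log units; beyond the scatter) by this estimate. In this assay the estimate for compound 4 is 2 nM within an expected range (0.1 nM to 40 nM).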

Compound 4, half-maximal inhibitory concentration: 3.73 nM
Beside the measured number, compound 4's estimate is 1.9-fold (0.27 log units) below it; measured number inside the range.
By their numbers in this assay, from the lowest: compound 3; then compound 4; then compound 1; then compound 2.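

In this assay, the fluoro group ortho to a methoxy group proves to be a sensitive position: replacing it with hydroxy gives a 29-fold higher number from compound 3 to compound 4 (1.46 log units; beyond the scatter). Until now, every large step had come from the other ring substituent, so this shows that the fluoro position also affects the read-out. The change adds a hydrogen-bond donor and acceptor, but nothing available explains the rise. Going by these compounds, how an amine or a chlorine atom would fare on this carbon remains open, as does whether the step would keep its size without the methoxy group.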